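From quinolin-8-yl to 1H-indol-4-yl on a shared core

This account rests on a few compounds, and the source may have more. Where it says the series, first, only, none or still open, it means among the compounds named here.

In a functional assay on DU-145 cells (Homo sapiens) for inhibition, read by trypan blue exclusion, with a stated time of 72 h (a lower number here means a stronger inhibitor, a higher number a weaker inhibitor), compound 3 (`Cc1ccc(S(=O)(=O)c2cc3cnc(Nc4cccc5cccnc45)nc3n(C)c2=O)cc1`) gives 10000 nM. That value lies within the scatter of compound 2 (`Cn1c(=O)c(S(=O)(=O)c2ccc(Cl)cc2)cc2cnc(Nc3cccc4[nH]ccc34)nc21`), which gives 5000 nM. Compound 1 (`Cc1ccc(S(=O)(=O)c2cc3cnc(Nc4cnc5[nH]ccc5c4)nc3n(C)c2=O)cc1`) gives 25000 nM, and the measured step is a 2.5-fold lower number from compound 1 to compound 3 (0.40 log units; beyond the scatter). This modest step arose when quinolin-8-yl took the place of another group on a nitrogen on an aromatic ring, so it bears on the same place but not on the same exchange.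

Compound 4 (`Cc1ccc(S(=O)(=O)c2cc3cnc(Nc4cccc5[nH]ccc45)nc3n(C)c2=O)cc1`) now carries 1H-indol-4-yl in place of quinolin-8-yl on that nitrogen: 1H-indol-4-yl in place of quinolin-8-yl on a nitrogen on an aromatic ring. The closest guide is compound 2, at 5000 nM, which also carries 1H-indol-4-yl there and differs from compound 4 elsewhere. Among the measured compounds shown here, no measured step isolates the new exchange, so the expectation remains loose. The expected step, no larger than the scatter, is a 1.8-fold lower number from compound 3 to compound 4 (0.26 log units; within the scatter). For compound 4, the estimated value is 5500 nM, with an expected range from 2000 nM to 13000 nM.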

Compound 4, half-maximal inhibitory concentration: 10000 nM
Compound 4: middle estimate off by 1.8-fold (0.26 log units), on the low side, within the range that was stated.
By their numbers in this assay, from the lowest: compounds 2, 3 and 4 (each within the scatter of the next); then compound 1.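

In this assay, the exchange of quinolin-8-yl for 1H-indol-4-yl on a nitrogen on an aromatic ring can now be read directly and gives no change at the digits printed from compound 3 to compound 4 (within the scatter), so these two groups cannot be told apart here, even though their hydrogen-bond donor and acceptor counts differ. With 1H-indol-4-yl held fixed, methyl in place of chloro on an aromatic carbon gives a 2.0-fold higher number from compound 2 to compound 4 (0.30 log units; within the scatter), whereas the group on that nitrogen in compound 1 remains set apart, with a 2.5-fold lower number from compound 1 to compound 4 (0.40 log units; beyond the scatter). No measurement offered here accounts for any of these results. On these data alone, what remains open is whether another group on that nitrogen, such as a plain phenyl or a phenyl carrying a morpholine, would bring the number below those of compound 3 and compound 4. As far as these compounds go, it is also open whether methoxy on that aromatic carbon would separate from methyl and chloro.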